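Methyl on the pyridine ring: a second look at one change

A few compounds are considered here, and "the series" means these few. Any claim that something is new, unique, unknown or untested is made for them only; others in the source may bear on it.

Compound 2 `N/C(=N\NC(=S)N1CCSCC1)c1ccccn1` gives 34% in a functional assay on A-375 cells (Homo sapiens) for cytotoxicity, read by MTT assay, with a stated time of 72 h, tested at 1 uM; on this read-out higher numbers stand for more inhibition of growth at the one concentration tested and lower numbers for less inhibition of growth. Compound 1 `Cc1cccc(/C(N)=N/NC(=S)N2CCSCC2)n1` differs from it by methyl in place of hydrogen on an aromatic carbon; in this assay compound 1 gives 47.2%, and this change made a number 13.2 percentage points higher from compound 2 to compound 1 (beyond the scatter). Compound 3 `N/C(=N\NC(=S)N1CCCCC1)c1ccccn1` differs from compound 2 in its core by piperidin-1-yl in place of thiomorpholin-4-yl on a thiocarbonyl carbon, giving a number 38.5 percentage points higher from compound 2 to compound 3 (beyond the scatter); compound 3 reaches 72.5%, the highest of the three. Compound 4 `Cc1ccnc(/C(N)=N/NC(=S)N2CCCCC2)c1` differs from compound 3 by methyl in place of hydrogen on an aromatic carbon. Going by the values given here, this is the same kind of change as the one from compound 2 to compound 1, but not the same: there the methyl sits next to the ring nitrogen, meta to a large group, while here it sits meta to a large group, opposite the ring nitrogen. A step of about a number 5.5 percentage points higher from compound 3 to compound 4 (within the scatter) is expected for compound 4, a little smaller than the earlier one, because compound 3 already stands at 72.5%. Compound 4 is therefore estimated at 78%.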

Compound 4, percent growth inhibition at one concentration: 33.5%
Compound 4: the middle estimate sits 44.5 percentage points above what was measured; measured number outside the range, below it.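

In this assay, methyl in place of hydrogen on an aromatic carbon does not carry over from one core to the other, and the two steps point in opposite directions: the same change on two cores in this assay, a number 13.2 percentage points higher (beyond the scatter) from compound 2 to compound 1 and a number 39 percentage points lower (beyond the scatter) from compound 3 to compound 4, 52.2 percentage points apart, beyond the scatter of two such steps. The new step is large, with a number 39 percentage points lower from compound 3 to compound 4 (beyond the scatter). This does not show why the steps differ, since the two pairs differ both at the thiocarbonyl carbon and in where the methyl sits on the ring, and two pairs cannot separate these differences.

From the compounds shown here alone, it remains open what methyl opposite the ring nitrogen would do with thiomorpholin-4-yl in place of piperidin-1-yl. Going by these compounds, how an ethyl group, a methoxy group or an amine would behave at that same place also remains open.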